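Notes on the step from compound 3 to compound 4

This account rests on a few compounds, and the source may have more. Where it says the series, first, only, none or still open, it means among the compounds named here.

For the measured compounds named here, in a functional assay on A-431 cells (Homo sapiens) for antiproliferative activity, read by MTT assay, with a stated time of 72 h (on this read-out lower numbers stand for stronger inhibition and higher numbers for weaker inhibition), compound 3 `O=C(Nc1cccc(CN2CCCC2)c1)Nc1ccc2ncnc(Nc3cccc(C(F)(F)F)c3)c2c1` gives 1230 nM, one of only two numbers in hand; compound 2 `O=C(Nc1cccc(CN2CCCCC2)c1)Nc1ccc2ncnc(Nc3cccc(C(F)(F)F)c3)c2c1` gives 1330 nM, and the step of a 1.1-fold lower number from compound 2 to compound 3 (0.03 log units; within the scatter) lies within the scatter. For compound 1 `C[C@@H](Nc1ncnc2ccc(NC(=O)Nc3ccc(CN4CCN(C)CC4)cc3)cc12)c1ccccc1` this assay reports only a limit, > 10000 nM (the limit of > 10000 nM in this assay, at which 1 of the 3 values shown sits). Compound 4 `CN1CCN(CCNC(=O)Nc2ccc3ncnc(Nc4cccc(C(F)(F)F)c4)c3c2)CC1` differs from compound 3 by 2-(4-methylpiperazin-1-yl)ethyl in place of 3-((pyrrolidin-1-yl)methyl)phenyl on an amide-type nitrogen. Going by the values given here, the one measured step exchanges one saturated ring for another and leaves the aromatic part of the tail untouched, so no measured pair bears on replacing that aromatic part with a chain. The change is therefore expected to give the step of a 3.3-fold higher number from compound 3 to compound 4 (0.51 log units; beyond the scatter) in this assay, toward a higher number, with wide uncertainty. Compound 4 is estimated at 4000 nM, range 1000 nM to 20000 nM.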

Compound 4, half-maximal inhibitory concentration: > 10000 nM
Compound 4 ended at the assay's limit; the forecaster's own chance of this, stated with the estimate: 35%; at least 2.5-fold (0.39 log units) between middle value and limit.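

In this assay, changing the tail on the amide-type nitrogen moves the read-out beyond the scatter: an at least 8.1-fold higher number from compound 3 to compound 4 (0.91 log units; beyond the scatter). The earlier step, a 1.1-fold lower number from compound 2 to compound 3 (0.03 log units; within the scatter), only exchanged one saturated ring for another, whereas 2-(4-methylpiperazin-1-yl)ethyl in place of 3-((pyrrolidin-1-yl)methyl)phenyl also removes the six-membered aromatic ring from the tail. Compound 4 carries a limit, not a number: the limit of > 10000 nM in this assay, at which 2 of the 4 values shown sit.

The compounds shown do not separate the loss of the aromatic ring from the change of amine. A 2-(pyrrolidin-1-yl)ethyl chain or a 3-((4-methylpiperazin-1-yl)methyl)phenyl group on the same nitrogen would separate them.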